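Dimethylamino for Methoxy on a Hydroxylated Core

The compounds below may be only part of what the source reports. "The series", "measured", "known", "first", "only" and "open" are said of these compounds alone.

Compound 1, `COc1ccc(-c2ccc(-c3ccc(-c4nc5ccccc5[nH]4)cc3)cc2)cc1`: 47200 nM
Compound 2, `CN(C)c1ccc(-c2ccc(-c3ccc(-c4nc5ccccc5[nH]4)cc3)cc2)cc1`: 39300 nM
Compound 3, `COc1ccc(-c2ccc(-c3ccc(-c4nc5c(O)cccc5[nH]4)cc3)cc2)cc1`: 4900 nM

Of the compounds shown here, three have been measured in a functional assay on KB cells (Homo sapiens) for inhibition, read by sulforhodamine B assay; on this read-out lower numbers stand for stronger inhibition of growth and higher numbers for weaker inhibition of growth. Compound 1 gives 47200 nM, compound 2 gives 39300 nM, and compound 3 gives 4900 nM. Compound 1 and compound 2 differ by dimethylamino in place of methoxy on an aromatic carbon, and this change produced a 1.2-fold lower number from compound 1 to compound 2 (0.08 log units; within the scatter). Compound 1 and compound 3 differ by hydroxy in place of hydrogen on an aromatic carbon, and this change produced a 9.6-fold lower number from compound 1 to compound 3 (0.98 log units; beyond the scatter), the only difference among the three that reaches beyond the scatter. Compound 3 therefore stands lowest of the three values, with the nearest measured neighbour well separated from it.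

Compound 4, `CN(C)c1ccc(-c2ccc(-c3ccc(-c4nc5c(O)cccc5[nH]4)cc3)cc2)cc1`, has not yet been measured in this assay. Going by the values given here, it differs from compound 3 by dimethylamino in place of methoxy on an aromatic carbon, which is the same change as the one from compound 1 to compound 2; the two cores differ by hydroxy in place of hydrogen on an aromatic carbon. Since that change gave only a 1.2-fold lower number from compound 1 to compound 2 (0.08 log units; within the scatter) on the core of compound 1, the step from compound 3 to compound 4 is expected to be small as well, namely a 1.2-fold lower number from compound 3 to compound 4 (0.08 log units; within the scatter). Among the compounds with values here, this expectation rests on the single earlier instance of the change and on compound 3 giving 4900 nM. Compound 4 is accordingly estimated at 4100 nM, with a plausible range from 1800 nM to 9500 nM.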

Compound 4, concentration for 50% growth inhibition: 4200 nM
For compound 4 the middle estimate is 1.0-fold (0.01 log units) below the measured one; low and high end bracket the measured number.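

In this assay, dimethylamino in place of methoxy gives a 1.2-fold lower number from compound 3 to compound 4 (0.07 log units; within the scatter), and this step on the hydroxylated core matches the one on the core of compound 1: the same change on two cores in this assay, a 1.2-fold lower number (0.08 log units; within the scatter) from compound 1 to compound 2 and a 1.2-fold lower number (0.07 log units; within the scatter) from compound 3 to compound 4, 1.0-fold (0.01 log units) apart, within the scatter of two such steps Hydroxy in place of hydrogen gives a 9.4-fold lower number from compound 2 to compound 4 (0.97 log units; beyond the scatter), so the step seen with the methoxy group recurs with the dimethylamino group: the same change on two cores in this assay, a 9.6-fold lower number (0.98 log units; beyond the scatter) from compound 1 to compound 3 and a 9.4-fold lower number (0.97 log units; beyond the scatter) from compound 2 to compound 4, 1.0-fold (0.01 log units) apart, within the scatter of two such steps Across these compounds, each change behaves the same whichever form the other place takes, but this rests on one pair of groups at each place, tested only in this assay, and it does not show that either change would carry over to a different core or explain why the hydroxy group is tied to the lower number.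

The compounds shown leave open whether a different group in place of methoxy, such as an ethoxy group, a morpholine ring or a longer chain, would also leave the number unmoved. They also leave open whether the step tied to hydroxy would survive with a methoxy group, an amine or a carboxylic acid standing in its place.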